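Swapping tert-butyl for phenyl on a carbonyl carbon

The compounds below may be only part of what the source reports. "The series", "measured", "known", "first", "only" and "open" are said of these compounds alone.

Measured in an ADME assay on HaCaT cells (Homo sapiens) for cytotoxicity, read by MTT assay, with a stated time of 48 h; on this read-out lower numbers stand for an effect already at smaller amounts and higher numbers for an effect only at larger amounts of compound:
- compound 1 `CCCCOC(=O)[C@@H](N)CCC(=O)NCCSC(=O)c1ccccc1`: 97000 nM
- compound 2 `CCCOC(=O)[C@@H](N)CCC(=O)NCCSC(C)=O`: 548000 nM
- compound 3 `CCCOC(=O)[C@@H](N)CCC(=O)NCCSC(=O)C(C)(C)C`: 152000 nM

Among these three, compound 3 at 152000 nM cannot be told apart from compound 1 at 97000 nM, since the two values lie within the usual scatter. Within the data shown here, compound 2 stands clearly apart from compound 3, as the one measured step shows: a 3.6-fold lower number from compound 2 to compound 3 (0.56 log units; beyond the scatter).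

The next compound is compound 4 `CCCOC(=O)[C@@H](N)CCC(=O)NCCSC(=O)c1ccccc1`. It keeps the core of compound 3 and has phenyl in place of tert-butyl on a carbonyl carbon whose other neighbour is sulfur: phenyl in place of tert-butyl on a carbonyl carbon.

Among the measured compounds shown here, no measured step makes this exact swap. The nearest evidence is the modest step of a 3.6-fold lower number from compound 2 to compound 3 (0.56 log units; beyond the scatter), made at the same carbonyl carbon. Compound 1 also helps, since it already carries phenyl there, though with a butyl rather than a propyl ester chain, and it gives 97000 nM. Both point to a number close to that of compound 3, with no change beyond the scatter expected.

The expected change in this assay is a 1.2-fold lower number from compound 3 to compound 4 (0.07 log units; within the scatter).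

The estimated value for compound 4 is 130000 nM, with an expected range from 70000 nM to 250000 nM.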

Compound 4, half-maximal effective concentration: 75000 nM
Compound 4: middle estimate off by 1.7-fold (0.24 log units), on the high side, within the range that was stated.
By their numbers in this assay, from the lowest: compounds 4, 1 and 3 (each within the scatter of the next, the first and the last beyond it); then compound 2.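

In this assay the swap on the carbonyl carbon whose other neighbour is sulfur gives a 2.0-fold lower number from compound 3 to compound 4 (0.31 log units; beyond the scatter) and so separates phenyl from tert-butyl at this place, though only just past the usual scatter. Alongside a 7.3-fold lower number from compound 2 to compound 4 (0.86 log units; beyond the scatter) it puts the three groups in one order among the compounds that share the propyl ester: methyl gives the highest number, tert-butyl a lower one and phenyl the lowest. The ester chain shows no such separation, since a 1.3-fold lower number from compound 1 to compound 4 (0.11 log units; within the scatter) stays within the scatter and compound 1 and compound 4 cannot be told apart, at least with phenyl on the carbonyl carbon.

No outside measurement bears on why the numbers fall in this order. Still open, going by these compounds, is whether a longer chain or an amine on this carbonyl carbon would continue the order, and whether changing the ester chain would also make no readable difference with methyl or tert-butyl in that place.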